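The compounds below may be only part of what the source reports. "The series", "measured", "known", "first", "only" and "open" are said of these compounds alone.

Compound 1 `C=C1[C@H](n2ccc(=O)[nH]c2=O)O[C@H](CO)[C@H]1O`: > 500000 nM (a limit)
Compound 2 `C=C1[C@H](n2cnc3c(O)nc(N)nc32)O[C@H](CO)[C@H]1O`: 150000 nM

Among the measured compounds shown here, in a functional assay on MT4 cells (Homo sapiens) for inhibition (a higher number here means a weaker inhibitor, a lower number a stronger inhibitor), compound 2 gives 150000 nM, the only actual number so far. For compound 1, > 500000 nM is a limit of the assay and not a number.

Compound 3 `C=C1[C@H](n2cnc3c(SC)nc(N)nc32)O[C@H](CO)[C@H]1O` has methylsulfanyl in place of hydroxy on an aromatic carbon. For the measured compounds named here, no measured step covers this exchange, so the expectation is loose. A moderate move towards stronger inhibition in this assay is expected, as an estimated step of a 2.5-fold lower number from compound 2 to compound 3 (0.40 log units; beyond the scatter). For compound 3 the estimated value is 60000 nM, with an expected range of 10000 nM to 300000 nM.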

Compound 3, half-maximal inhibitory concentration: > 500000 nM
Compound 3 gave a limit, no number (the forecaster's own chance of this, stated with the estimate: 25%); at least 8.3-fold (0.92 log units) between middle value and limit.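

In this assay, methylsulfanyl in place of hydroxy on an aromatic carbon gives an at least 3.3-fold higher number from compound 2 to compound 3 (0.52 log units; beyond the scatter), so this position does not accept the exchange without a loss of inhibition. Compound 3 gives > 500000 nM, a limit of the assay and not a number. The step therefore has a floor but no measured size: the limit of > 500000 nM in this assay, at which 2 of the 3 values shown sit.

Going by these compounds, it remains open whether the loss follows the departure of hydroxy or the arrival of methylsulfanyl. An amino group, a methoxy group or a chlorine atom at this position would help to separate the two.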